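Small two-nitrogen-ring head groups on a phenylethynyl stem

A few compounds are considered here, and "the series" means these few. Any claim that something is new, unique, unknown or untested is made for them only; others in the source may bear on it.

compound 1, `CCNc1ncc(C#Cc2ccccc2)cn1` — "not active" (no number reported)
compound 2, `CC(C)(C)c1ncc(C#Cc2ccccc2)cn1` — 247000 nM
compound 3, `Cc1ncc(C#Cc2ccccc2)cn1` — "not active" (no number reported)

Three compounds share one stem and differ only in the group on the carbon of the six-membered ring that carries two nitrogen atoms. In an assay on HEK293 cells for positive allosteric modulation of metabotropic glutamate receptor 5 (Rattus norvegicus) (a higher number here means that more compound is needed for the effect, a lower number that less compound is needed), compound 1 is reported as not active. In this assay, going by the values given here, compound 2 gives 247000 nM, a very weak effect and the only number in the set. In this assay compound 3 is likewise reported as not active, so compound 3 stands without a number, as one of two entries of that kind here; nothing can be said about its size against compound 2.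

The next compound, compound 4 `COc1ncc(C#Cc2ccccc2)cn1`, is reached from compound 3 by methoxy in place of methyl on an aromatic carbon. Among the compounds with values here, no measured pair shows this change, so its size is unknown. Given the weakness of compound 2 and the absence of a number for compound 3, no step beyond the scatter is expected in this assay, and a report of no activity is the most likely outcome. Should a number be obtained, compound 4 is expected to give about 200000 nM, within 40000 nM to 1000000 nM.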

Compound 4, half-maximal effective concentration: "not active" (no number reported)
The entry for compound 4 holds no number, and the estimate cannot be compared.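

In this assay, going by these compounds alone, compound 3 and compound 4 both stand without a number, so no step from methyl to methoxy can be read. No evidence bears on this result. The compounds shown leave open whether compound 2, with 247000 nM as the only number, can be surpassed by any other group at this place.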